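Fluoro for methyl on the fused ring: cytotoxicity notes

The compounds below may be only part of what the source reports. "The series", "measured", "known", "first", "only" and "open" are said of these compounds alone.

Three compounds of the series have been run in an ADME assay on Vero cells (Chlorocebus sabaeus) for cytotoxicity, read by MTT assay, with a stated time of 72 h; on this read-out higher numbers stand for lower toxicity in this test and lower numbers for higher toxicity in this test. Compound 3 `COc1c(N2C[C@H]3CCCN(Cc4cn(CCCN5C(=O)C(=O)c6cc(C)ccc65)nn4)[C@H]3C2)c(F)cc2c(=O)c(C(=O)O)cn(C3CC3)c12` gives 32 ug/mL, compound 2 `COc1c(N2C[C@H]3CCCN(Cc4cn(CCCN5C(=O)C(=O)c6cc(F)ccc65)nn4)[C@H]3C2)c(F)cc2c(=O)c(C(=O)O)cn(C3CC3)c12` gives 16 ug/mL, and compound 1 `CO/N=C1/C(=O)N(CCCn2cc(CN3CCC[C@@H]4CN(c5c(F)cc6c(=O)c(C(=O)O)cn(C7CC7)c6c5OC)C[C@@H]43)nn2)c2ccc(C)cc21` gives 8 ug/mL. Compound 3 and compound 2 differ in one place, (fluoro in place of methyl on an aromatic carbon), and this change made a 2.0-fold lower number from compound 3 to compound 2 (0.30 log units; within the scatter). Compound 1 and compound 3 carry different cores; the difference between the two cores is not broken down here. Compound 4 `CO/N=C1/C(=O)N(CCCn2cc(CN3CCC[C@@H]4CN(c5c(F)cc6c(=O)c(C(=O)O)cn(C7CC7)c6c5OC)C[C@@H]43)nn2)c2ccc(F)cc21` is not yet measured. It stands to compound 1 as compound 2 stands to compound 3, the change being (fluoro in place of methyl on an aromatic carbon), the same change in the same place. The step from compound 1 to compound 4 is expected to be a 2.0-fold lower number from compound 1 to compound 4 (0.30 log units; within the scatter) because a 2.0-fold lower number from compound 3 to compound 2 (0.30 log units; within the scatter) followed the same change. Compound 4 is therefore estimated at 4 ug/mL in this assay, with the expected range running from 2 ug/mL to 10 ug/mL.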

Compound 4, half-maximal cytotoxic concentration: 4 ug/mL
For compound 4 middle estimate and measured number coincide at the digits printed; the range from low to high includes it.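

In this assay, fluoro in place of methyl on an aromatic carbon gives a 2.0-fold lower number from compound 1 to compound 4 (0.30 log units; within the scatter), and this step sits close to the one seen on the other core: the same change on two cores in this assay, a 2.0-fold lower number (0.30 log units; within the scatter) from compound 3 to compound 2 and a 2.0-fold lower number (0.30 log units; within the scatter) from compound 1 to compound 4, 1.0-fold (0.00 log units) apart, within the scatter of two such steps

On these two cores, then, the change carries over with no measurable difference in size. Each step lies within the scatter, however, so the pair does not establish that the change shifts cytotoxicity at all, and two cores do not make a rule for the series.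

Still open, on these data alone, is whether chloro or a nitrile on the same aromatic carbon would move the number beyond the scatter on either core. Also open, as far as these compounds go, is whether the match holds on a third core.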